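The compounds below may be only part of what the source reports. "The series", "measured", "known", "first", "only" and "open" are said of these compounds alone.

Working notes on the series. Within the data shown here, compound 1, `C=C1C[C@]23C[C@@]1(O)CC[C@H]2c1ccc(O)c(C)c1[C@@H]3Cn1cc(-c2ccc(C(F)(F)F)cc2)nn1`, is the only compound with a number in a functional assay on MCF7 cells (Homo sapiens) for cytotoxicity, read by MTT assay, with a stated time of 4 days; on this read-out lower numbers stand for stronger inhibition and higher numbers for weaker inhibition: compound 1 gives 12400 nM. Compound 2, `C=C1C[C@]23C[C@@]1(O)CC[C@H]2c1ccc(OS(=O)(=O)c2ccc(C)cc2)c(C)c1[C@@H]3Cn1cc(-c2ccc(C(F)(F)F)cc2)nn1`, reaches only the limit of the assay, and in this assay compound 2 gives > 20000 nM, a limit and not a number. Among the measured compounds shown here, the single measured step, an at least 1.6-fold higher number from compound 1 to compound 2 (0.20 log units; that floor lies within the scatter), concerns the oxygen on the aromatic ring and is bounded by the limit of > 20000 nM in this assay, at which 1 of the 2 values shown sits. Compound 3, `C=C1C[C@]23C[C@@]1(O)CC[C@H]2c1ccc(O)c(C)c1[C@@H]3Cn1cc(-c2ccc(Cl)cc2)nn1`, differs from compound 1 elsewhere: chloro in place of trifluoromethyl on an aromatic carbon. Cut one bond further out, the change reads 4-(trifluoromethyl)phenyl to 4-chlorophenyl. No measured step touches this position, so the only step shown gives no direct guidance, and there is no basis for expecting a move beyond the scatter in either direction. The step is therefore expected to be a 1.0-fold lower number from compound 1 to compound 3 (0.01 log units; within the scatter). Compound 3 is estimated at 12000 nM, with a range from 5000 nM to 30000 nM. Since the limit of the assay lies close to this estimate, a limit rather than a number is a real possibility for compound 3.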

Compound 3, half-maximal inhibitory concentration: > 20000 nM
Compound 3: a limit, no number; the forecaster's own chance of this, stated with the estimate: 30%; at least 1.6-fold (0.22 log units) between middle value and limit.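

In this assay, among these compounds, this is the first reading at the position on the aromatic carbon para to a large group: chloro in place of trifluoromethyl gives an at least 1.6-fold higher number from compound 1 to compound 3 (0.20 log units; that floor lies within the scatter). The step is only a floor, so it fixes neither how far the number for compound 3 lies from that of compound 1 nor whether the change at this position exceeds the scatter at all. Together with the change at the oxygen on the aromatic ring, this makes a second place on compound 1 where a single change ends at a limit instead of a number, and both steps are bounded in the same way: the limit of > 20000 nM in this assay, at which 2 of the 3 values shown sit.

Compound 1 remains the only compound with a number in this assay, so the compounds shown give no size for a change at either place and no direction beyond these floors. From the compounds shown here alone, whether a methoxy group, a nitrile or an amine at the position of the trifluoromethyl would give a number or another limit remains open, as does whether any group there would give a lower number than compound 1.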